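Series notes: aryl swap on the ring carbon, compound 4

The source may hold more compounds than are shown below. What is called first, only, known or untested is meant among the compounds shown, and "the series" means these compounds.

Compound 1 `Fc1cccc(-c2nn3c(CCc4ccccc4)nnc3s2)c1` in an assay for inhibition of histone-lysine N-methyltransferase, H3 lysine-79 specific (Homo sapiens), with stated times of 15 min and 120 min, tested at 50 uM (a lower number here means less inhibition, a higher number more inhibition at the concentration tested (going by the name of the read-out)), gives 18%. Among the compounds with values here, compound 2 `Fc1cccc(-c2nn3c(CSc4ccccc4)nnc3s2)c1` gives 21% in this assay, and the one measured step, a number 3 percentage points higher from compound 1 to compound 2 (within the scatter), changes only the substituent on the saturated chain carbon. Compound 3 `Brc1cccc(-c2nn3c(Cn4cnc5ccccc54)nnc3s2)c1` gives 62% in this assay, the highest of the three numbers; its gap to compound 2 and its larger gap to compound 1 both lie beyond the scatter, though each gap spans two changes at once, the chain substituent and the group on the aromatic carbon.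

Compound 4 `Cc1ccc(-c2nn3c(Cn4cnc5ccccc54)nnc3s2)cc1C` differs from compound 3 in one place: 3,4-dimethylphenyl in place of 3-bromophenyl on an aromatic carbon. Within the data shown here, no measured step bears on this position; the step from compound 1 to compound 2 sits elsewhere and was small, within the scatter. Both groups are six-membered carbon-only aromatic rings without donors or acceptors, and the chain substituent of compound 3, the one seen with the high number, is kept. The expectation is therefore anchored to compound 3 with wide uncertainty in either direction. Compound 4 is expected to give about 50% in this assay, estimated between 25% and 75%. The estimated step is a number 12 percentage points lower from compound 3 to compound 4 (beyond the scatter).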

Compound 4, a percentage reported as inhibition, at one concentration (the size of the read-out at that concentration, not a potency): 72%
Compound 4: the middle estimate sits 22 percentage points below what was measured, within the range that was stated.
By their numbers in this assay, from the lowest: compounds 1 and 2 (each within the scatter of the next); then compounds 3 and 4 (each within the scatter of the next).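

Within the data shown here, this is the first step read at the aryl group on the aromatic carbon of the five-membered aromatic ring, and in this assay 3,4-dimethylphenyl in place of 3-bromophenyl gives a number 10 percentage points higher from compound 3 to compound 4 (within the scatter). The exchange removes the bromine and adds two methyl groups to the six-membered aromatic ring of carbon only, yet with the chain substituent of compound 3 kept, compound 4 still stands at 72%, so the bromine is not needed for a number of this size at this position. No measurement given here accounts for the closeness of the two numbers or links either group to a property.

On these data alone, both aryl groups compared here are carbon-only aromatic rings without hydrogen-bond donors or acceptors, so the effect of an amine or a carboxylic acid on that ring, or of a saturated cyclohexyl ring in its place, remains open. Also open, as far as these compounds go, is whether 3,4-dimethylphenyl gives a similar number alongside the chain substituents of compound 1 and compound 2, which would show whether this position behaves independently of the chain.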